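Bromo Added Beside a Hydroxy on an Inactive Amide

The source may hold more compounds than are shown below. What is called first, only, known or untested is meant among the compounds shown, and "the series" means these compounds.

Compound 2 `O=C(Nc1ccc(Sc2nc3ccccc3s2)c(Cl)c1)c1cccc(Br)c1` was tested in an assay on isolated protein for inhibition of thiosulfate sulfurtransferase (Homo sapiens), with a stated time of 60 min, in the absence of a further agent; on this read-out lower numbers stand for stronger inhibition and higher numbers for weaker inhibition. In this assay compound 2 gives only a limit of the assay, > 100000 nM. Compound 1 `O=C(Nc1ccc(Sc2nc3ccccc3s2)c(Cl)c1)c1cc(Br)cc(Br)c1` differs from it by bromo in place of hydrogen on an aromatic carbon. In this assay compound 1 also gives only a limit, > 100000 nM. The step between them, a step that the two limits leave unreadable from compound 2 to compound 1, cannot be read because of the limit of > 100000 nM in this assay, at which 3 of the 3 values shown sit.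

Compound 3 `O=C(Nc1ccc(Sc2nc3ccccc3s2)cc1)c1ccccc1O` has another core; the difference between the two cores is not broken down here. In this assay compound 3 gives only a limit, > 100000 nM. Compound 4 `O=C(Nc1ccc(Sc2nc3ccccc3s2)cc1)c1cccc(Br)c1O` is not yet measured and differs from compound 3 by bromo in place of hydrogen on an aromatic carbon. This is the same kind of change as from compound 2 to compound 1, though the place is not the same: there the bromo sits meta to a bromo group, here ortho to a hydroxy group, in both cases meta to a large group. The expectation rests on compound 3 and on the unreadable step that the two limits leave unreadable from compound 2 to compound 1. The step from compound 3 to compound 4 is expected to be a step that the limit leaves unreadable from compound 3 to compound 4. Compound 4 is therefore expected to give about 150000 nM, most likely again only a limit, between 30000 nM and 1000000 nM.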

Compound 4, half-maximal inhibitory concentration: > 100000 nM
Compound 4: only a limit was reported; the forecaster's own chance of this, stated with the estimate: 85%; the middle value is on the limit's open side.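

The step from compound 3 to compound 4 cannot be read, because both compounds give only a limit in this assay: the limit of > 100000 nM in this assay, at which 4 of the 4 values shown sit. The compounds shown leave open how they rank against one another and whether adding a bromo changes inhibition at all.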